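A Chlorine Returns to the Aryl Ring of Compound 4

The source may report more compounds than this note shows. Statements on the series, on what has been measured and on what is new or still open speak of the compounds shown alone.

Three compounds share one core and differ only in the aryl group on the carbon with a double bond to nitrogen. In a functional assay on A549 cells (Homo sapiens) for cytotoxicity, read by XTT assay, with a stated time of 24 h (on this read-out lower numbers stand for stronger inhibition and higher numbers for weaker inhibition), compound 1 `Fc1ccc(/C=N/NC(=S)Nc2cccc3ccccc23)cc1Cl` gives 51.3 ug/mL. Compound 2 `Fc1cc(F)cc(/C=N/NC(=S)Nc2cccc3ccccc23)c1` gives 500 ug/mL in this assay, and compound 3 `Fc1ccc(F)c(/C=N/NC(=S)Nc2cccc3ccccc23)c1` gives 500 ug/mL. Within the data shown here, compound 3 thus stands level with compound 2, the two together the highest numbers of the three, while a 9.7-fold higher number from compound 1 to compound 3 (0.99 log units; beyond the scatter) is the only step beyond the scatter, and no change at the digits printed from compound 2 to compound 3 (within the scatter) shows that the two difluoro patterns cannot be told apart.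

Compound 4 `Fc1cccc(Cl)c1/C=N/NC(=S)Nc1cccc2ccccc12` carries 2-chloro-6-fluorophenyl in place of 2,5-difluorophenyl on a carbon with a double bond to nitrogen. The step that bears most on it is a 9.7-fold higher number from compound 1 to compound 3 (0.99 log units; beyond the scatter), where giving up the chlorine for a second fluorine raised the number; a 9.7-fold higher number from compound 1 to compound 2 (0.99 log units; beyond the scatter) agrees. Compound 4 brings a chlorine back, though in a different pattern from compound 1, so a modest fall in the number is expected, with a 3.3-fold lower number from compound 3 to compound 4 (0.52 log units; beyond the scatter). Compound 4 is estimated at 150 ug/mL in this assay, within a range from 40 ug/mL to 500 ug/mL.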

Compound 4, half-maximal inhibitory concentration: 125 ug/mL
Estimate against measurement, compound 4: 1.2-fold (0.08 log units) above; the measured number falls inside the stated range.
By their numbers in this assay, from the lowest: compound 1; then compound 4; then compounds 2 and 3 (each within the scatter of the next).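

In this assay, the two groups that carry a chlorine on the carbon with a double bond to nitrogen both give lower numbers than the difluorophenyl groups, with a 4.0-fold lower number from compound 3 to compound 4 (0.60 log units; beyond the scatter) and a 4.0-fold lower number from compound 2 to compound 4 (0.60 log units; beyond the scatter) showing that this is not confined to compound 1. The chlorine pattern also counts at this position: a 2.4-fold higher number from compound 1 to compound 4 (0.39 log units; beyond the scatter) separates 2-chloro-6-fluorophenyl from 3-chloro-4-fluorophenyl, whereas the two difluoro patterns could not be told apart. Nothing in the data shown accounts for these steps.

The compounds shown leave open whether chlorine itself is what lowers the number, as no ring here carries chlorine alone or two chlorines. They also leave open how this position would respond to a methoxy group, an amine or a carboxylic acid on the aryl ring.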